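A few compounds are considered here, and "the series" means these few. Any claim that something is new, unique, unknown or untested is made for them only; others in the source may bear on it.

Compound 1 `C#CCSc1nnc(C)n1N1C(=O)c2ccccc2C1=O` in a functional assay on MKN-45 cells (Homo sapiens) for cytotoxicity, read by MTT assay, with a stated time of 48 h (a higher number here means a weaker inhibitor, a lower number a stronger inhibitor), gives > 200000 nM, which is a limit of the assay. Compound 2 `CSc1nnc(C)n1N1C(=O)c2ccccc2C1=O` in this assay gives > 200000 nM, again a limit. Compound 3 `C=CCSc1nnc(CC)n1N1C(=O)c2ccccc2C1=O` in this assay gives > 200000 nM, also a limit.

Compound 3 therefore stands at the limit of > 200000 nM in this assay, at which 3 of the 3 values shown sit. Within the data shown here, the single measured step, a step that the two limits leave unreadable from compound 1 to compound 2, is left unreadable by the two limits. Compound 4 `CCc1nnc(SCC(=O)c2ccccc2)n1N1C(=O)c2ccccc2C1=O` differs from compound 3 by benzoyl in place of vinyl on a saturated chain carbon bound to a sulfur. Among the measured compounds shown here, no measured step bears on this change, and the only measured step carries no readable size, so neither direction nor magnitude can be drawn from the data. Compound 4 is estimated in this assay at 100000 nM, within a range from 20000 nM to 500000 nM. For the measured compounds named here, the expected step of an at least 2.0-fold lower number from compound 3 to compound 4 (0.30 log units; that floor lies within the scatter) rests on no measured precedent and remains an open guess.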

Compound 4, half-maximal inhibitory concentration: > 200000 nM
Compound 4: no number, only a limit (the forecaster's own chance of this, stated with the estimate: 60%); middle value at least 2.0-fold (0.30 log units) from the limit.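

Among these compounds, compound 3 and compound 4 both give only a limit in this assay, so no step between them can be read: the limit of > 200000 nM in this assay, at which 4 of the 4 values shown sit. The compounds shown leave open what change, if any, would give a readable number.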